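The compounds below may be only part of what the source reports. "The series", "measured", "known", "first", "only" and "open" are said of these compounds alone.

Measured so far in a physicochemical assay for solubility, read by turbidimetry, measured as kinetic solubility, at pH 7.4; on this read-out lower numbers stand for lower solubility and higher numbers for higher solubility:
compound 1 `CC(C)(C)c1cc(C(=O)Nc2nc(CN)cs2)n(-c2ccccc2)n1`: 160 ug/mL
compound 2 `CC(C)(C)c1cc(C(=O)Nc2nc(CN)cs2)n(Cc2ccc(Cl)cc2)n1`: > 200 ug/mL, a limit of the assay and not a number
compound 3 `CC(C)(C)c1cc(C(=O)Nc2nc(CN)cs2)n(Cc2ccccc2Cl)n1`: 80 ug/mL

Compound 3 gives the lowest of the two numbers; its nearest neighbour is compound 1, a 2.0-fold lower number from compound 1 to compound 3 (0.30 log units; within the scatter), and the remaining value for the series is a limit. Compound 4 `CC(C)(C)c1cc(C(=O)Nc2nc(CN)cs2)n(Cc2ccc(Br)cc2)n1` is not yet measured; it carries 4-bromophenyl in place of 2-chlorophenyl on a saturated chain carbon bound to an aromatic nitrogen. Among the measured compounds shown here, the one measured step that bears on this change is an at least 2.5-fold lower number from compound 2 to compound 3 (0.39 log units; beyond the scatter), which set compound 3 apart from the rest. Going back from the 2-chlorophenyl to a 4-bromophenyl is expected to undo most of that step in this assay. Compound 4 is therefore expected to give a higher number, a 1.8-fold higher number from compound 3 to compound 4 (0.24 log units; within the scatter), estimated at 140 ug/mL with a range of 60 ug/mL to 300 ug/mL, and the assay may again return only a limit.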

Compound 4, solubility: > 200 ug/mL
Compound 4 ended at the assay's limit; the forecaster's own chance of this, stated with the estimate: 30%; middle value at least 1.4-fold (0.15 log units) from the limit.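

In this assay compound 4 gives > 200 ug/mL, a limit of the assay and not a number. On the saturated chain carbon, the 4-bromophenyl gives an at least 2.5-fold higher number from compound 3 to compound 4 (0.39 log units; beyond the scatter), so compound 3 now stands apart from both the 4-chlorobenzyl and the 4-bromobenzyl compounds, not from one alone. Against the phenyl on the aromatic nitrogen, the reading is an at least 1.2-fold higher number from compound 1 to compound 4 (0.09 log units; that floor lies within the scatter), which sets no firm order.

Going by these compounds, the bromo to chloro step between compound 2 and compound 4 cannot be read because both values are limits: the limit of > 200 ug/mL in this assay, at which 2 of the 4 values shown sit. Still open is how an amine or a carboxylic acid in place of the 4-bromophenyl, or a longer chain in place of the 4-bromobenzyl, would read.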